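Working notes on compound 3 in the cytotoxicity series

The source may hold more compounds than are shown below. What is called first, only, known or untested is meant among the compounds shown, and "the series" means these compounds.

Measured so far:
compound 1 `Cc1ccc(NC(=S)OCCNC(=O)c2cccnc2)cc1` — > 800000 nM
compound 2 `O=C(Oc1ccc(-c2cc(=S)ss2)cc1)c1cccnc1` — > 800000 nM

Both results come from an ADME assay on RAW264.7 cells (Mus musculus) for cytotoxicity, read by MTT assay, with a stated time of 48 h; a higher number here means a weaker inhibitor, a lower number a stronger inhibitor. For compound 1 the value > 800000 nM is a limit of the assay, not a number. For compound 2 the value > 800000 nM is likewise a limit of the assay. The whole picture so far is the limit of > 800000 nM in this assay, at which 2 of the 2 values shown sit. Compound 1 therefore stands at the limit, and nothing on the numbers shown separates it from compound 2: the two values show only that both are limits, and no measured step exists between them.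

Compound 3 `O=C(NCCOC(=S)Nc1ccc(F)cc1)c1cccnc1` has not yet been measured in this assay. It differs from compound 1 in one place: fluoro in place of methyl on an aromatic carbon. Among the measured compounds shown here, since no measured step is available, the step expected in this assay is a step that the limit leaves unreadable from compound 1 to compound 3, that is, none beyond the scatter, in no particular direction. Compound 3 is accordingly expected to give an estimated 1000000 nM, with a range from 400000 nM to 3000000 nM, and most probably the assay again returns only a limit rather than a number.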

Compound 3, half-maximal inhibitory concentration: > 800000 nM
Compound 3: only a limit was reported; the forecaster's own chance of this, stated with the estimate: 85%; the middle value is on the limit's open side.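

No step from compound 1 to compound 3 can be read, as the results for both compounds are limits of the assay and not numbers: the limit of > 800000 nM in this assay, at which 3 of the 3 values shown sit.

The compounds shown leave open whether any of them gives a measured number in this assay, and so what size of step, if any, the change from 4-methylphenyl to 4-fluorophenyl brings.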